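A few compounds are considered here, and "the series" means these few. Any claim that something is new, unique, unknown or untested is made for them only; others in the source may bear on it.

Compound 1, `Cc1c(-c2cncc(-c3ccc(C(N)=O)c(OC(C)C)c3)c2)cnn1C`: 60 nM in an assay on cells for inhibition of MAP kinase-interacting serine/threonine-protein kinase 1 (Homo sapiens), read by mobility shift assay, with stated times of 10 min and 60 min, in the presence of a further agent that is not named here; a higher number here means a weaker inhibitor, a lower number a stronger inhibitor
Compound 2, `NC(=O)c1ccc(-c2cccnc2)cc1OC1CCC1`: 1900 nM in this assay

Of the two numbers measured in this assay, compound 2 stands at the higher one, and the gap to compound 1 is well beyond the usual scatter. Compound 3, `CC(C)Oc1cc(-c2cccnc2)ccc1C(N)=O`, has not been measured. It differs from compound 2 in one place: isopropyl in place of cyclobutyl on an oxygen on an aromatic ring. Going by the values given here, no step between two measured compounds covers this change, so the data give no direct guide to its size. Compound 1 also carries an isopropoxy group, but it differs from compound 2 in other places as well, so nothing can be read from its value about this change alone. Compound 3 is therefore expected to stay close to compound 2, with a step of a 1.1-fold higher number from compound 2 to compound 3 (0.02 log units; within the scatter) that is not beyond the scatter. The estimate for compound 3 in this assay is 2000 nM, with a range from 700 nM to 6000 nM.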

Compound 3, half-maximal inhibitory concentration: 880 nM
The estimate for compound 3 lay 2.3-fold (0.36 log units) above the measured number; low and high end bracket the measured number.
By their numbers in this assay, from the lowest: compound 1; then compound 3; then compound 2.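

In this assay, isopropyl in place of cyclobutyl on the oxygen gives a 2.2-fold lower number from compound 2 to compound 3 (0.33 log units; beyond the scatter), the first sign that the number responds to the group at this position. Compound 3 also isolates the second place of difference: hydrogen in place of 1,5-dimethyl-1H-pyrazol-4-yl on an aromatic carbon gives a 15-fold higher number from compound 1 to compound 3 (1.17 log units; beyond the scatter), a larger step than the one at the oxygen. No measurement available explains the size of either step.

On these data alone, it remains open how methyl, ethyl or cyclopropyl on the same oxygen would compare with isopropyl. Also open, as far as these compounds go, is whether the change from cyclobutyloxy to isopropoxy has a step of similar size when 1,5-dimethyl-1H-pyrazol-4-yl is present on the core.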